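A few compounds are considered here, and "the series" means these few. Any claim that something is new, unique, unknown or untested is made for them only; others in the source may bear on it.

Compound 1, with the structure `Cn1c(=O)[nH]c2cc(OCCCc3ccccc3)ccc21`, opens the account. For the measured compounds named here, in an assay on cells for inhibition of Amine oxidase [flavin-containing] B (Homo sapiens), read by fluorescence, with stated times of 30 min and 15 min, tested at 1 uM (on this read-out lower numbers stand for less inhibition and higher numbers for more inhibition at the one concentration tested (going by the name of the read-out)), compound 1 gives "not active" (no number reported), so no single number marks where it stands; the read-out records only that the compound showed no inhibition at the one concentration tested. A second compound with a different core, compound 2, has the structure `O=C1Nc2ccc(OCc3ccc(Cl)c(Cl)c3)cc2C1=O`; in this assay compound 2 gives 95.7%. The two results cannot be joined by a step, since no change in one place connects them.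

The step followed here runs from compound 1 to compound 3, whose structure is `Cn1c(=O)[nH]c2cc(OCCc3ccccc3)ccc21`. The difference between the two is phenyl in place of benzyl on a saturated chain carbon, two bonds along the chain from an oxygen on an aromatic ring. Going by the values given here, compound 1 is the only reference point for this step, and no measured step exists for the change.

No change beyond the scatter in this assay is expected for compound 3; its inhibition is estimated at 10%, within a range from 0% to 35%.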

Compound 3, a percentage reported as inhibition, at one concentration (the size of the read-out at that concentration, not a potency): "not active" (no number reported)
Compound 3 has no reported number here, so the estimate cannot be set against anything.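

Compound 1 and compound 3 both lack a number in this assay and so no step can be read between them. No measured evidence bears on this result. The compounds shown leave open whether any change to the chain or core of compound 1 would give measurable inhibition.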